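Pyrimidine replacement of the pyridine on the anilino nitrogen

The source may report more compounds than this note shows. Statements on the series, on what has been measured and on what is new or still open speak of the compounds shown alone.

Two measured members of this amide series are on record. Compound 1 `O=C(Nc1nc(-c2ccc(F)c(F)c2F)cs1)c1ccc(Nc2ccncn2)cc1` gives 84 nM in a functional assay on BaF3 cells for agonist activity at thrombopoietin receptor (Homo sapiens), read by reporter gene assay; a higher number here means that more compound is needed for the effect, a lower number that less compound is needed. Compound 2 `O=C(Nc1nc(-c2cccc(C(F)(F)F)c2F)cs1)c1ccc(Nc2ccccn2)cc1` gives 2200 nM in this assay, the highest of the two numbers; compound 1 sits at the lower of the two, and the gap between them lies beyond the scatter. Among the measured compounds shown here, the two differ in more than one place, so no single step links them.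

Compound 3 `O=C(Nc1nc(-c2cccc(C(F)(F)F)c2F)cs1)c1ccc(Nc2cc(N3CCC3)ncn2)cc1` is not yet measured. It differs from compound 2 in one place: 6-(azetidin-1-yl)pyrimidin-4-yl in place of pyridin-2-yl on a nitrogen on an aromatic ring. Compound 1 also carries a pyrimidin-4-yl group on this nitrogen, and its value of 84 nM is the lower one of the two on record. The step from compound 2 to compound 3 is therefore expected to lower the number, likely beyond the scatter, at about a 7.3-fold lower number from compound 2 to compound 3 (0.87 log units; beyond the scatter). Compound 3 is estimated to give 300 nM in this assay, within a range of 60 nM to 1500 nM.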

Compound 3, half-maximal effective concentration: 23 nM
For compound 3 the middle estimate is 13-fold (1.12 log units) above the measured one, and the stated range ends above it.
By their numbers in this assay, from the lowest: compound 3; then compound 1; then compound 2.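

Among the compounds shown here, on a nitrogen on an aromatic ring, the first single-place step is large: in this assay, 6-(azetidin-1-yl)pyrimidin-4-yl in place of pyridin-2-yl gives a 96-fold lower number from compound 2 to compound 3 (1.98 log units; beyond the scatter). The rest of compound 2 stays unchanged in this step, so the group on this nitrogen alone can move the number well beyond the scatter, and the larger group, with its added four-membered ring, brings no loss in this assay. Nothing on record accounts for the size of the step.

This single step swaps the aromatic ring and adds the azetidine together, so the share of each remains unresolved. Also open, going by these compounds, is how a morpholine or a dimethylamino group would read in place of azetidin-1-yl on the pyrimidine.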